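The source may report more compounds than this note shows. Statements on the series, on what has been measured and on what is new or still open speak of the compounds shown alone.

Working notes on the series. Compound 1 `CN(Cc1nc2cc(C(F)(F)F)ccc2nc1-c1ccccc1)c1ccc(Cl)cc1` is taken as the reference; in an assay on isolated protein for inhibition of Dihydrofolate reductase (Homo sapiens), read by spectrophotometry (on this read-out higher numbers stand for weaker inhibition and lower numbers for stronger inhibition), compound 1 gives 5000 nM. Compound 2 `CN(Cc1nc2cc(C(F)(F)F)ccc2nc1-c1ccccc1)c1ccc(F)cc1` differs from compound 1 by fluoro in place of chloro on an aromatic carbon; in this assay compound 2 gives 5000 nM, and the step is no change at the digits printed from compound 1 to compound 2 (within the scatter). Compound 3 `C#CCN(Cc1nc2cc(C(F)(F)F)ccc2nc1-c1ccccc1)c1ccc(Cl)cc1` differs from compound 1 by ethynyl in place of hydrogen on a saturated chain carbon bound to a nitrogen on an aromatic ring; in this assay compound 3 gives 4000 nM, and the step is a 1.3-fold lower number from compound 1 to compound 3 (0.10 log units; within the scatter). Among the compounds with values here, no step is counted between compound 2 and compound 3; their two values alone show numbers that sit within the usual scatter of each other.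

Compound 4 `C#CCN(Cc1nc2cc(C(F)(F)F)ccc2nc1-c1ccccc1)c1ccc(F)cc1` has not been measured in this assay. Within the data shown here, it differs from compound 3 by fluoro in place of chloro on an aromatic carbon, which is the same change, at the same place, as the one from compound 1 to compound 2.

For compound 4 the expected step is a 1.1-fold higher number from compound 3 to compound 4 (0.05 log units; within the scatter). This expectation rests on the step of no change at the digits printed from compound 1 to compound 2 (within the scatter) and on compound 3 standing at 4000 nM. Compound 4 is therefore estimated at 4500 nM, with a likely range from 2500 nM to 8000 nM.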

Compound 4, inhibition constant: 8000 nM
Compound 4: the middle estimate sits 1.8-fold (0.25 log units) below what was measured, and the stated range covers the measured number.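

Fluoro in place of chloro gives a 2.0-fold higher number from compound 3 to compound 4 (0.30 log units; within the scatter) in this assay, and set beside the same change on the core of compound 1, the two steps do not differ: the same change on two cores in this assay, no change at the digits printed (within the scatter) from compound 1 to compound 2 and a 2.0-fold higher number (0.30 log units; within the scatter) from compound 3 to compound 4, 2.0-fold (0.30 log units) apart, within the scatter of two such steps

Ethynyl in place of hydrogen gives a 1.6-fold higher number from compound 2 to compound 4 (0.20 log units; within the scatter), and this change also reads the same on both cores: the same change on two cores in this assay, a 1.3-fold lower number (0.10 log units; within the scatter) from compound 1 to compound 3 and a 1.6-fold higher number (0.20 log units; within the scatter) from compound 2 to compound 4, 2.0-fold (0.30 log units) apart, within the scatter of two such steps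

All four steps lie within the scatter, so the series shows that neither change moves the number measurably on either of these two cores, but it does not show that a step large enough to read would carry from one core to the other.

Still open, on these data alone, is whether a group of another kind, such as an amine in place of the chloro or fluoro, or a carboxylic acid or longer chain in place of the ethynyl, would give a step beyond the scatter. Also open, as far as these compounds go, is how either change would behave on a core without the trifluoromethyl group.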